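The source may hold more compounds than are shown below. What is called first, only, known or untested is meant among the compounds shown, and "the series" means these compounds.

Measured so far in a functional assay on L1210 cells (Mus musculus) for antiproliferative activity; a lower number here means that less compound is needed, a higher number that more compound is needed for the effect:
compound 1, `CCCCCCCCCCCCO/N=C/c1cc(OC)c2c(c1OC)C(=O)C=CC2=O` — 0.311 ug/mL
compound 2, `CCCCCC/C(=N\OCCC)c1cc(OC)c2c(c1OC)C(=O)C=CC2=O` — 0.166 ug/mL

Only these two numbers are known. Compound 1 and compound 2 lie within the usual scatter of each other, so no ordering between them can be drawn from this assay, and compound 1 simply stands alongside compound 2.

Compound 3, `CCCCCCCCCO/N=C/c1cc(OC)c2c(c1OC)C(=O)C=CC2=O`, has not yet been measured in this assay. It differs from compound 1 in a single place: hydrogen in place of propyl on a saturated chain carbon, nine bonds along the chain from an oxygen on an unsaturated carbon. Going by the values given here, no step between two measured compounds bears on this change, since compound 1 and compound 2 differ from one another in more than one place. The expectation therefore rests on compound 1 alone. Compound 3 is expected to give about 0.3 ug/mL in this assay, within a range from 0.1 ug/mL to 0.9 ug/mL. The step this implies, a 1.0-fold lower number from compound 1 to compound 3 (0.02 log units; within the scatter), is expected to be small, with no clear direction beyond the scatter.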

Compound 3, concentration for half-maximal effect: 0.19 ug/mL
Beside the measured number, compound 3's estimate is 1.6-fold (0.20 log units) above it; measured number inside the range.
By their numbers in this assay, from the lowest: compounds 2, 3 and 1 (each within the scatter of the next).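

In this assay, putting hydrogen in place of propyl on a saturated chain carbon, nine bonds along the chain from an oxygen on an unsaturated carbon, gives a 1.6-fold lower number from compound 1 to compound 3 (0.21 log units; within the scatter). Going by these compounds alone, this is the first step that changes only this chain, and the same difference can be read as hexyl to propyl; at this position, removing these three carbons leaves the two compounds indistinguishable in this assay. No measurement shown offers an explanation for this result.

The compounds shown leave open whether a longer chain or a much shorter one, such as methyl, would stay within the scatter of compound 1. They also do not show whether an amine or a carboxylic acid at the end of the chain would do so.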